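The compounds below may be only part of what the source reports. "The series", "measured", "known", "first", "only" and "open" are said of these compounds alone.

Compound 1 `CN(C)CCCCOc1ccccc1/C=C/c1cccc(Cl)c1` gives 14.3% in a functional assay on the whole organism with Mus musculus as the target, in the maximal electroshock model, at a dose of 50 mg/kg by the oral route (on this read-out higher numbers stand for more inhibition at the one dose given (going by the name of the read-out) and lower numbers for less inhibition), the higher of the two numbers in hand; compound 2 `CN(C)CCCCOc1ccccc1/C=C/c1ccc(Cl)cc1` gives 0% in the same read-out. Within the data shown here, the only measured step is a number 14.3 percentage points lower from compound 1 to compound 2 (beyond the scatter), a change on the aromatic ring at the far end of the double-bonded chain, not at the amine.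

Compound 3 `OC1CCCN(CCCCOc2ccccc2/C=C/c2cccc(Cl)c2)C1` differs from compound 1 at the amine end: 3-hydroxypiperidin-1-yl in place of dimethylamino on a saturated chain carbon, four bonds along the chain from an oxygen on an aromatic ring.

Among the measured compounds shown here, no measured step touches the amine, so the step from compound 1 to compound 2 gives no direct guide to this change, beyond showing that the series can move by a modest amount on a single replacement. With nothing in hand on the amine, the expectation is a step within the scatter or a small one in either direction, a number 3.7 percentage points higher from compound 1 to compound 3 (within the scatter). Compound 3 is therefore estimated at 18%, with a range from 0% to 45%.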

Compound 3, a percentage reported as inhibition, in the whole organism at one dose (the size of the read-out at that dose, not a potency): 12.5%
Beside the measured number, compound 3's estimate is 5.5 percentage points above it; low and high end bracket the measured number.
By their numbers in this assay, from the lowest: compound 2; then compounds 3 and 1 (each within the scatter of the next).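

In this assay, the change at the amine end gives a number 1.8 percentage points lower from compound 1 to compound 3 (within the scatter), so a dimethylamino group and a 3-hydroxypiperidin-1-yl group cannot be told apart at this position, four bonds along the chain from an oxygen on an aromatic ring. A six-membered ring with a hydroxyl group is therefore accommodated here without a reading beyond the scatter, whereas the chlorine shift on the far ring gave a number 14.3 percentage points lower from compound 1 to compound 2 (beyond the scatter). Nothing in hand explains either step.

Open, from the compounds shown here alone, is whether the hydroxyl group matters at all, which piperidin-1-yl or morpholin-4-yl at the same place would test. Also open, going by these compounds, is whether a 3-hydroxypiperidin-1-yl group changes the reading with the 4-chlorophenyl end of compound 2 , or with a longer chain between the oxygen and the amine.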